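One Small Change Tried on Two Different Cores

The source may hold more compounds than are shown below. What is called first, only, known or untested is meant among the compounds shown, and "the series" means these compounds.

Of the compounds shown here, three have been measured in a functional assay on B16-F10 cells (Mus musculus) for inhibition, read by colorimetric assay and MTT assay, with a stated time of 72 h; on this read-out higher numbers stand for weaker inhibition and lower numbers for stronger inhibition. Compound 1 `COc1ccc(C(=O)NNC(=S)Nc2csc(-c3ccc(C)cc3)c2)cc1` gives 9000 nM in this assay. Compound 2 `Cc1ccc(-c2cc(NC(=S)NNC(=O)c3ccc(O)cc3)cs2)cc1` differs from compound 1 in one spot only, and in this assay compound 2 gives 48000 nM. The change that turns compound 1 into compound 2 is hydrogen in place of methyl on an oxygen on an aromatic ring, and it made a 5.3-fold higher number from compound 1 to compound 2 (0.73 log units; beyond the scatter), so the inhibition became modestly weaker.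

Compound 3 `COc1ccc(-c2nnc(Nc3csc(-c4ccccc4)c3)s2)cc1` is built on a different core; the difference between the two cores is not broken down here. In this assay compound 3 gives 6000 nM. Its gap to compound 1 lies within the usual scatter of such measurements, while its gap to compound 2 lies beyond it.

Compound 4 `Oc1ccc(-c2nnc(Nc3csc(-c4ccccc4)c3)s2)cc1` has not yet been measured. It differs from compound 3 by hydrogen in place of methyl on an oxygen on an aromatic ring, the same change that turned compound 1 into compound 2, at the same place on each core. Since that change made a 5.3-fold higher number from compound 1 to compound 2 (0.73 log units; beyond the scatter), the expectation is that it acts alike on the core of compound 3, and the estimated step is a 5.0-fold higher number from compound 3 to compound 4 (0.70 log units; beyond the scatter). This rests on a single earlier example, so the range around the estimate is kept wide. Compound 4 is therefore expected to give about 30000 nM in this assay, most likely between 12000 nM and 80000 nM.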

Compound 4, half-maximal inhibitory concentration: 8000 nM
For compound 4 the middle estimate is 3.8-fold (0.57 log units) above the measured one; the measured number lies below the stated range.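

In this assay, putting hydroxy in place of methoxy on the core of compound 3 gave a 1.3-fold higher number from compound 3 to compound 4 (0.12 log units; within the scatter), so on this core the swap left no clear mark on the result. Among these compounds, the change therefore did not carry over at the same size from one core to the other, and the effect seen on the first core was not a reliable guide to the second: the same change on two cores in this assay, a 5.3-fold higher number (0.73 log units; beyond the scatter) from compound 1 to compound 2 and a 1.3-fold higher number (0.12 log units; within the scatter) from compound 3 to compound 4, 4.0-fold (0.60 log units) apart, beyond the scatter of two such steps This does not show why the two cores respond differently, or which part of them matters, and with only one pair on each core it cannot say how a third core would respond.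

The compounds shown carry only methoxy or hydroxy at this spot, so it remains open how an amine, a carboxylic acid or a longer chain such as ethoxy would behave there on either core. Going by these compounds, it also remains open whether the gap between the two steps would hold up with further pairs on these cores, or whether it would appear at all in cells other than the ones used here.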